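A Fluorine Swap Tried on Two Related Cores

The source may report more compounds than this note shows. Statements on the series, on what has been measured and on what is new or still open speak of the compounds shown alone.

Compound 1, `Cn1cnc2c(Sc3ccccc3)ncnc21`, gives 8%.
Compound 2, `Cn1cnc2c(Sc3ccc(F)cc3)ncnc21`, gives 5%.
Compound 3, `Cn1cnc2c(-c3ccccc3)ncnc21`, gives 8%.

All three numbers come from an assay on isolated protein for inhibition of Ca2+/calmodulin-dependent protein kinase II (CaM kinase II) (Rattus norvegicus), tested at 30 uM; on this read-out lower numbers stand for less inhibition and higher numbers for more inhibition at the one concentration tested (going by the name of the read-out). Compound 1 and compound 2 share one core; they differ only by fluoro in place of hydrogen on an aromatic carbon. That change produced a number 3 percentage points lower from compound 1 to compound 2 (within the scatter), so the two readings cannot be told apart. Compound 3 carries a different core, and the difference between the two cores is not broken down here; its reading sits level with that of compound 1, and together these are the highest of the three numbers, though all three lie within the scatter of one another.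

Compound 4, `Cn1cnc2c(-c3ccc(F)cc3)ncnc21`, has not yet been measured. It stands to compound 3 exactly as compound 2 stands to compound 1, namely by fluoro in place of hydrogen on an aromatic carbon, and the surroundings of the changed position are the same in both pairs, so this is the same change made a second time.

The expected step is a number 3 percentage points lower from compound 3 to compound 4 (within the scatter), because a number 3 percentage points lower from compound 1 to compound 2 (within the scatter) on the first core was small. Compound 4 is therefore expected to give 5%, with a range of -5% to 15%, given that compound 3 shows 8% and the same change on the other core barely moved the reading.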

Compound 4, a percentage reported as inhibition, at one concentration (the size of the read-out at that concentration, not a potency): 12%
For compound 4 the middle estimate is 7 percentage points below the measured one; measured number inside the range.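

The fluoro swap on the core of compound 3 gave a number 4 percentage points higher from compound 3 to compound 4 (within the scatter). Set beside the same swap on the core of compound 1 in this assay, the comparison reads: the same change on two cores in this assay, a number 3 percentage points lower (within the scatter) from compound 1 to compound 2 and a number 4 percentage points higher (within the scatter) from compound 3 to compound 4, 7 percentage points apart, within the scatter of two such steps. This shows that the change moved the reading beyond the scatter on neither core, and that the opposite directions of the two steps carry no weight; it does not show that the two cores would respond alike to a change with a larger effect, as all four readings come from one concentration and none stands clear of the others, and two pairs of compounds make no rule for the whole series.

The compounds shown have only hydrogen or fluoro at this place on the six-membered aromatic ring, which leaves open how an amine, a carboxylic acid or a longer chain there would read on either core. They also leave open whether any compound of this kind can reach a level of inhibition that stands clearly above the scatter.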